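Swapping formyl for 2-cyanoethenyl in a weak cytotoxic compound

The source may report more compounds than this note shows. Statements on the series, on what has been measured and on what is new or still open speak of the compounds shown alone.

Going by the values given here, in a functional assay on Raji cells (Homo sapiens) for cytotoxicity, with a stated time of 72 h (a higher number here means that more compound is needed for the effect, a lower number that less compound is needed), compound 2 `COc1ccc(/C=C/[C@@](C)(/C=C/c2ccc(O)c(C=O)c2)CCC=C(C)C)cc1` gives 13000 nM and this is the only true number so far. Compound 1 `C=C[C@@](C)(/C=C/c1ccc(O)c(/C=C/C#N)c1)CCC=C(C)C` shows > 26000 nM in this assay as a limit of the assay and not a number. Compound 3 `COc1ccc(/C=C/[C@@](C)(/C=C/c2ccc(O)c(/C=C/C#N)c2)CCC=C(C)C)cc1` has 2-cyanoethenyl in place of formyl on an aromatic carbon, a change counted as 2-cyanoethenyl in place of formyl on an aromatic carbon and made ortho to a hydroxy group. Among the compounds with values here, no measured step gives the size of this change. A small step toward a higher number is expected, a 1.2-fold higher number from compound 2 to compound 3 (0.09 log units; within the scatter) and it would stay within the usual scatter. For compound 3 the estimated value is 16000 nM with an expected range of 6000 nM to 30000 nM in this measurement.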

Compound 3, half-maximal effective concentration: > 26000 nM
Compound 3 ended at the assay's limit (the forecaster's own chance of this, stated with the estimate: 35%); middle value at least 1.6-fold (0.21 log units) away from the limit.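

On the aromatic carbon ortho to a hydroxy group, 2-cyanoethenyl in place of formyl gives an at least 2.0-fold higher number from compound 2 to compound 3 (0.30 log units; that floor lies within the scatter) in this assay. Compound 3 carries a limit of the assay and not a number, so this step has a floor but no known size, and the swap brings no lower number: the limit of > 26000 nM in this assay, at which 2 of the 3 values shown sit. The step between compound 1 and compound 3 cannot be read, as both are limits.

Still open, as far as these compounds go, is whether an amine or a carboxylic acid at this position would give a lower number than compound 2, at 13000 nM. From the compounds shown here alone, how far compound 3 lies past its limit also remains unknown.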